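Working notes: compound 4 as the next step from compound 3

A few compounds are considered here, and "the series" means these few. Any claim that something is new, unique, unknown or untested is made for them only; others in the source may bear on it.

Values in a functional assay on PC-3 cells (Homo sapiens) for cytotoxicity, read by MTT assay, with a stated time of 72 h (a higher number here means a weaker inhibitor, a lower number a stronger inhibitor), for the three measured compounds:
compound 1 `O=C(Nc1ccc(Oc2ccnc3[nH]ccc23)cc1)c1nn(-c2ccc(Cl)cc2)ccc1=O` gives 32400 nM
compound 2 `O=C(Nc1ccc(Oc2ccnc3[nH]ccc23)c(F)c1)c1nn(-c2ccc(Cl)c(F)c2)ccc1=O` gives 13600 nM
compound 3 `Cc1cc(=O)n(-c2cccc(F)c2)nc1C(=O)Nc1ccc(Oc2ncnc3[nH]ccc23)cc1` gives 14600 nM

Compound 3 holds the second highest number of the three. Compound 2 sits closest to it, and the gap between compound 3 and compound 2 is within the scatter, so no order between them can be read. Compound 1 gives a higher number than compound 3, and that gap lies beyond the scatter.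

Compound 4 `Cc1cc(=O)n(-c2ccccc2OC(F)(F)F)nc1C(=O)Nc1ccc(Oc2ncnc3[nH]ccc23)cc1` is not yet measured. The change from compound 3 is 2-(trifluoromethoxy)phenyl in place of 3-fluorophenyl on an aromatic nitrogen. Among the compounds with values here, no measured pair in this set shares that change, so nothing here sets its size. With the measured numbers spread over a narrow band, compound 4 is expected to stay near compound 3, and the step from compound 3 to compound 4 is expected to be about a 1.0-fold higher number from compound 3 to compound 4 (0.01 log units; within the scatter), which is no more than the scatter in either direction. Compound 4 is therefore estimated at 15000 nM, with a range from 5000 nM to 45000 nM.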

Compound 4, half-maximal inhibitory concentration: 22500 nM
For compound 4 the middle estimate is 1.5-fold (0.18 log units) below the measured one; the measured number falls inside the stated range.
By their numbers in this assay, from the lowest: compounds 2, 3, 4 and 1 (each within the scatter of the next, the first and the last beyond it).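

The first step readable in this series sets 2-(trifluoromethoxy)phenyl in place of 3-fluorophenyl on the aromatic nitrogen and gives a 1.5-fold higher number from compound 3 to compound 4 (0.19 log units; within the scatter) in this assay. At this position, then, an aryl group with more heavy atoms and a hydrogen-bond acceptor in its substituent leaves the number within the scatter, something compounds 1 to 3 could not show because none of them forms a one-place pair. Nothing measured explains the size of this step.

Within the data shown here, the single step changes both the substituent and its place on the phenyl ring, so the two contributions cannot be separated. Also open, from the compounds shown here alone, is whether a phenyl ring carrying an amine or a carboxylic acid, or a longer alkyl chain in place of the phenyl ring, would shift the number beyond the scatter.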